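A few compounds are considered here, and "the series" means these few. Any claim that something is new, unique, unknown or untested is made for them only; others in the source may bear on it.

Measured in a functional assay on HL-60 cells (Homo sapiens) for antiproliferative activity, with a stated time of 72 h; a lower number here means a stronger inhibitor, a higher number a weaker inhibitor:
compound 1 `OC[C@H]1O[C@@H](n2cnc3c(NCc4ccc(Cl)cc4)ncnc32)[C@H](O)[C@@H]1O`: 1700 nM
compound 2 `COc1cc(CNc2ncnc3c2ncn3[C@@H]2O[C@H](CO)[C@@H](O)[C@H]2O)cc(OC)c1`: 20200 nM
compound 3 `OC[C@H]1O[C@@H](n2cnc3c(NCc4ccc(F)cc4F)ncnc32)[C@H](O)[C@@H]1O`: 3400 nM

Compound 1 gives the lowest of the three numbers in this assay. Its nearest companion is compound 3, a 2.0-fold higher number from compound 1 to compound 3 (0.30 log units; within the scatter), a gap within the scatter, so no order between the two is claimed. Compound 2 lies furthest off, a 12-fold higher number from compound 1 to compound 2 (1.07 log units; beyond the scatter), and the remaining step, a 5.9-fold lower number from compound 2 to compound 3 (0.77 log units; beyond the scatter), points the same way: the 2,4-difluorophenyl compound sits much nearer compound 1 than the 3,5-dimethoxyphenyl compound does.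

Compound 4 `OC[C@H]1O[C@@H](n2cnc3c(NCc4c(F)ccc(F)c4F)ncnc32)[C@H](O)[C@@H]1O` has not been measured. Against compound 1 the change is 2,3,6-trifluorophenyl in place of 4-chlorophenyl on a saturated chain carbon bound to a nitrogen on an aromatic ring. The step bearing most closely on it is a 2.0-fold higher number from compound 1 to compound 3 (0.30 log units; within the scatter), where a fluorinated phenyl replaced the same 4-chlorophenyl without moving beyond the scatter; a 12-fold higher number from compound 1 to compound 2 (1.07 log units; beyond the scatter) and a 5.9-fold lower number from compound 2 to compound 3 (0.77 log units; beyond the scatter) bear less directly, as both involve the 3,5-dimethoxyphenyl group. For compound 4 the expected step is therefore a 2.1-fold higher number from compound 1 to compound 4 (0.31 log units; beyond the scatter), at most a modest rise in the number rather than a change on the scale seen with the dimethoxy compound. In this assay compound 4 is estimated at 3500 nM, with a range from 1200 nM to 10000 nM.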

Compound 4, half-maximal inhibitory concentration: 13000 nM
Compound 4: the middle estimate sits 3.7-fold (0.57 log units) below what was measured; measured number above the stated range.
By their numbers in this assay, from the lowest: compounds 1 and 3 (each within the scatter of the next); then compounds 4 and 2 (each within the scatter of the next).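

In this assay, a fluorinated phenyl on this saturated chain carbon does not by itself keep the number close to that of the 4-chlorophenyl compound: the 2,3,6-trifluorophenyl group gives a 7.6-fold higher number from compound 1 to compound 4 (0.88 log units; beyond the scatter) and, set against the 2,4-difluorophenyl group, a 3.8-fold higher number from compound 3 to compound 4 (0.58 log units; beyond the scatter) so the outcome at this position depends on which fluorinated phenyl is present. The 3,5-dimethoxyphenyl group is also no longer alone at the high end of the series, as a 1.6-fold lower number from compound 2 to compound 4 (0.19 log units; within the scatter) places these two groups within the scatter of each other, so a rise of this order does not require methoxy groups. No supporting data accompany these numbers, and the difference between the two fluorinated phenyl groups remains unexplained.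

The pair of compound 3 and compound 4 does not separate the number of fluorine atoms from their placement on the phenyl ring, so either could underlie the step. Also open, going by these compounds, is how the position responds to an unsubstituted phenyl, to a phenyl bearing an amine or a carboxylic acid, or to a longer chain between the ring nitrogen substituent and the phenyl.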